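Adding a Third Methoxy Group to Compound 3

The compounds below may be only part of what the source reports. "The series", "measured", "known", "first", "only" and "open" are said of these compounds alone.

Of the compounds shown here, three have been tested in a functional assay on MCF7 cells (Homo sapiens) for cytotoxicity, read by MTT assay, with a stated time of 48 h; on this read-out lower numbers stand for stronger inhibition and higher numbers for weaker inhibition. Compound 1 `COc1cc(-c2cc(C(=O)Nc3nc4ccc(Cl)cc4s3)nc3cc(-c4ccccc4)nn23)cc(OC)c1OC` gives 30200 nM, compound 2 `Cc1cc2nc(NC(=O)c3cc(-c4ccc(F)cc4)n4nc(-c5ccccc5)cc4n3)sc2cc1C` gives 17000 nM, and compound 3 `COc1ccc(-c2cc(C(=O)Nc3nc4cc(C)c(C)cc4s3)nc3cc(-c4ccccc4)nn23)cc1OC` gives 2510 nM, the lowest of the three numbers. For the measured compounds named here, the only single-point comparison among them is the step of a 6.8-fold lower number from compound 2 to compound 3 (0.83 log units; beyond the scatter), which shows that swapping one group on the aromatic carbon can move the result clearly beyond the scatter.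

Compound 4 `COc1cc(-c2cc(C(=O)Nc3nc4cc(C)c(C)cc4s3)nc3cc(-c4ccccc4)nn23)cc(OC)c1OC` differs from compound 3 in one place: methoxy in place of hydrogen on an aromatic carbon. Going by the values given here, no measured step tests this exact change. Compound 4 would carry the same 3,4,5-trimethoxyphenyl group as compound 1, yet the two differ elsewhere in the molecule as well. So the value of compound 1, 30200 nM, can only hint that the trimethoxy pattern has not so far gone with a low number. On that basis compound 4 is expected to give a higher number than compound 3, an estimated step of a 2.4-fold higher number from compound 3 to compound 4 (0.38 log units; beyond the scatter) in this assay. Compound 4 is therefore estimated at 6000 nM, with a range from 1500 nM to 25000 nM.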

Compound 4, half-maximal inhibitory concentration: 2290 nM
Compound 4: the middle estimate sits 2.6-fold (0.42 log units) above what was measured, and the stated range covers the measured number.
By their numbers in this assay, from the lowest: compounds 4 and 3 (each within the scatter of the next); then compounds 2 and 1 (each within the scatter of the next).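

In this assay the third methoxy group, placed ortho to a methoxy group on the ring, gives a 1.1-fold lower number from compound 3 to compound 4 (0.04 log units; within the scatter) and so makes no readable difference, which shows that this spot on the 3,4-dimethoxyphenyl ring accepts the extra group with the number holding steady. The 3,4,5-trimethoxyphenyl group is also not tied to a high number: with the 5,6-dimethyl-1,3-benzothiazol-2-yl group kept on the amide-type nitrogen, replacing 4-fluorophenyl with it gives a 7.4-fold lower number from compound 2 to compound 4 (0.87 log units; beyond the scatter) in this series. With the 3,4,5-trimethoxyphenyl group held constant, the swap of 6-chloro-1,3-benzothiazol-2-yl for 5,6-dimethyl-1,3-benzothiazol-2-yl gives a 13-fold lower number from compound 1 to compound 4 (1.12 log units; beyond the scatter) and so ties the high number of compound 1 to the group on the amide-type nitrogen rather than to the trimethoxy pattern.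

Nothing available explains why these steps have the sizes they do. Still open, going by these compounds, is whether this spot would accept something other than methoxy, such as a hydroxyl group, an amine or a longer ethoxy chain, with the number again holding steady.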